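A few compounds are considered here, and "the series" means these few. Any claim that something is new, unique, unknown or untested is made for them only; others in the source may bear on it.

Measured so far:
- compound 1 `CCn1c(CN2CCN(C(=O)C3CC3)CC2)nc2ccccc21`: 20.8%
- compound 2 `Cc1cccc(Cn2c(CN3CCN(C(=O)c4ccncc4)CC3)nc3ccccc32)c1`: 20.6%
- compound 3 `Cc1cccc(Cn2c(CN3CCN(C(=O)c4cccs4)CC3)nc3ccccc32)c1`: 60.8%

In an assay on isolated protein for inhibition of aldehyde dehydrogenase 1A1 (Homo sapiens), read by spectrophotometry, tested at 10 uM (on this read-out lower numbers stand for less inhibition and higher numbers for more inhibition at the one concentration tested (going by the name of the read-out)), compound 1 stands second highest of the three numbers, with compound 2 within the scatter of it and compound 3 well above it. Going by the values given here, the one step that was measured, a number 40.2 percentage points higher from compound 2 to compound 3 (beyond the scatter), changes the group on the carbonyl carbon, a different place from the change now considered. Compound 4 `COc1cccc(Cn2c(CN3CCN(C(=O)C4CC4)CC3)nc3ccccc32)c1` differs from compound 1 by 3-methoxyphenyl in place of methyl on a saturated chain carbon bound to an aromatic nitrogen. Among the compounds with values here, no measured step touches this place; compound 2 already carries a benzyl-type group here and shows a number like that of compound 1, so no step beyond the scatter is expected. The estimate for compound 4 is 25% (range 5% to 50%), an expected step of a number 4.2 percentage points higher from compound 1 to compound 4 (within the scatter).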

Compound 4, a percentage reported as inhibition, at one concentration (the size of the read-out at that concentration, not a potency): 44.4%
Estimate against measurement, compound 4: 19.4 percentage points below; the range from low to high includes it.
By their numbers in this assay, from the lowest: compounds 2 and 1 (each within the scatter of the next); then compound 4; then compound 3.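

Going from ethyl to 3-methoxybenzyl gives, in this assay, a number 23.6 percentage points higher from compound 1 to compound 4 (beyond the scatter), the first step measured at this place. So the group on a saturated chain carbon bound to an aromatic nitrogen, and not only the group on the carbonyl carbon, can move the number beyond the scatter. No measured evidence bears on why the number rises here. Going by these compounds, it remains open whether the step comes from the phenyl ring or from its methoxy, which a plain benzyl group on the same core would help to separate. On these data alone, how an amine or a carboxylic acid on that ring would read is also open.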